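The source may report more compounds than this note shows. Statements on the series, on what has been measured and on what is new or still open speak of the compounds shown alone.

Compound 1 `Oc1ccc(/C=N/NC(=S)Nc2ccccc2)cc1` gives 242000 nM in an assay for inhibition of ribonucleoside-diphosphate reductase RR1 (Homo sapiens), with a stated time of 30 min (a higher number here means a weaker inhibitor, a lower number a stronger inhibitor), the highest of the three numbers recorded. Compound 2 `Cc1cccc(NC(=S)N/N=C/c2ccc(O)cc2)c1` gives 30400 nM and compound 3 `O=[N+]([O-])c1ccccc1NC(=S)N/N=C/c1ccc(O)cc1` gives 39300 nM; each carries one added group on an aromatic carbon of the shared core of compound 1, and each sits lower. Compound 4 `O=[N+]([O-])c1ccc(NC(=S)N/N=C/c2ccc(O)cc2)cc1` differs from compound 1 by nitro in place of hydrogen on an aromatic carbon. The step of a 6.2-fold lower number from compound 1 to compound 3 (0.79 log units; beyond the scatter) introduces the same group and bears most directly on this change; the step of an 8.0-fold lower number from compound 1 to compound 2 (0.90 log units; beyond the scatter) points the same way. A modest lowering is therefore expected, namely a 6.1-fold lower number from compound 1 to compound 4 (0.78 log units; beyond the scatter). Compound 4 is expected to give 40000 nM, with a range from 10000 nM to 150000 nM.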

Compound 4, half-maximal inhibitory concentration: 45100 nM
Beside the measured number, compound 4's estimate is 1.1-fold (0.05 log units) below it; measured number inside the range.
By their numbers in this assay, from the lowest: compounds 2, 3 and 4 (each within the scatter of the next); then compound 1.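

In this assay, nitro placed para to a large group gives a 5.4-fold lower number from compound 1 to compound 4 (0.73 log units; beyond the scatter), so the lowering is not tied to the one aromatic carbon that carries nitro in compound 3. Compound 3 and compound 4 lie within the usual scatter of each other, so these two nitro placements cannot be told apart here. On these data alone, whether an amine or a carboxylic acid at this same position would also lower the number remains open. Nothing measured here explains why nitro lowers it.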